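Changing the aryl group on the double-bonded chain carbon

A few compounds are considered here, and "the series" means these few. Any claim that something is new, unique, unknown or untested is made for them only; others in the source may bear on it.

compound 1 `O=C(/C(=C\c1ccc(Br)cc1)SCc1ccc(Cl)cc1)c1ccc(Br)cc1` gives 1000 nM
compound 2 `O=C(/C(=C\c1cccc(Cl)c1Cl)SCc1ccc(Cl)cc1)c1ccc(Br)cc1` gives 10000 nM

In a functional assay on DU-145 cells (Homo sapiens) for inhibition, read by trypan blue exclusion, with a stated time of 96 h (a lower number here means a stronger inhibitor of growth, a higher number a weaker inhibitor of growth), compound 2 stands highest of the two at 10000 nM and so is the weaker growth inhibitor. Compound 3 `COc1ccccc1/C=C(/SCc1ccc(Cl)cc1)C(=O)c1ccc(Br)cc1` differs from compound 2 by one change (2-methoxyphenyl in place of 2,3-dichlorophenyl on a double-bonded chain carbon bound to a double-bonded chain carbon). Going by the values given here, the one measured step bearing on this is the arrival of 2,3-dichlorophenyl at this place (a 10-fold higher number from compound 1 to compound 2 (1.00 log units; beyond the scatter)), which is modest in size. With that group leaving, a somewhat smaller step towards a lower number is expected (a 2.5-fold lower number from compound 2 to compound 3 (0.40 log units; beyond the scatter)) in this assay as well. Compound 3 is estimated at 4000 nM with an expected range from 800 nM to 15000 nM in this series.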

Compound 3, concentration for 50% growth inhibition: 1000 nM
Compound 3: the middle estimate sits 4.0-fold (0.60 log units) above what was measured; the measured number falls inside the stated range.
By their numbers in this assay, from the lowest: compounds 1 and 3 (each within the scatter of the next); then compound 2.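

In this assay, 2-methoxyphenyl on the double-bonded chain carbon gives a 10-fold lower number from compound 2 to compound 3 (1.00 log units; beyond the scatter), so the higher number at this place is not common to all the groups tried. Going by these compounds alone, the change from 4-bromophenyl gives no change at the digits printed from compound 1 to compound 3 (within the scatter), which leaves 2,3-dichlorophenyl as the only one of the three groups standing apart. Nothing at hand explains this difference between the groups.

Open, from the compounds shown here alone, is whether 2,3-dichlorophenyl is a lone exception or whether other groups at this place, such as an aminophenyl or a carboxyphenyl group, would also move the number.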